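Metabolic stability notes on the furan-linked series: compound 4

The source may hold more compounds than are shown below. What is called first, only, known or untested is meant among the compounds shown, and "the series" means these compounds.

Measured so far in an ADME assay on microsomes from liver (Rattus norvegicus) for metabolic stability, with a stated time of 10 min; on this read-out lower numbers stand for a less stable compound and higher numbers for a more stable compound:
- compound 1 `c1ccc2oc(-c3cn4nc(C5CC5)sc4n3)cc2c1`: 53%
- compound 2 `COc1cc(OCc2cccc(COc3ccccc3)c2)c2cc(-c3cn4nc(OC)sc4n3)oc2c1`: 64%
- compound 3 `c1ccc(Sc2nn3cc(-c4cc5ccccc5o4)nc3s2)cc1`: "not determined" (no result reported)

Compound 2 stands highest of the two numbers in this assay. Its nearest neighbour on the scale is compound 1, which lies lower by a margin beyond the usual scatter; compound 3 contributes no number and cannot be placed.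

The next compound, compound 4 `COc1cc(OCc2cccc(O)c2)c2cc(-c3cn4nc(OC)sc4n3)oc2c1`, differs from compound 2 in one place: hydroxy in place of phenoxymethyl on an aromatic carbon. Among the compounds with values here, no step between measured compounds touches this kind of change, so there is nothing within the set that fixes its size or direction. A step from compound 2 to compound 4 of a number 6 percentage points higher from compound 2 to compound 4 (within the scatter) is expected, which would keep the two within the scatter of each other or place compound 4 a little higher.

For compound 4 the remaining fraction in this assay is estimated at 70%, with a range from 50% to 90%.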

Compound 4, percent of the compound remaining: 49%
Compound 4: middle estimate off by 21 percentage points, on the high side; the measured number lies below the stated range.
By their numbers in this assay, from the lowest: compounds 4 and 1 (each within the scatter of the next); then compound 2.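

Within the data shown here, this is the first step that touches this position, and it gives the change a direction: in this assay, hydroxy in place of phenoxymethyl on an aromatic carbon gives a number 15 percentage points lower from compound 2 to compound 4 (beyond the scatter) and so does not preserve the standing of compound 2. The read-out therefore responds to the group at this place, on a six-membered aromatic ring of carbon only and meta to a large group, although this rests on a single pair. Nothing in the available data accounts for the size or direction of this step.

Among these compounds, the single pair does not separate the loss of phenoxymethyl from the arrival of hydroxy. As far as these compounds go, whether a methoxy group, an amine or a carboxylic acid at this place would track compound 2 or compound 4 remains open.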